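The compounds below may be only part of what the source reports. "The series", "measured", "known", "first", "only" and "open" are said of these compounds alone.

Measured compounds:
compound 1 `CS(=O)(=O)Nc1ccc2c(c1)S(=O)(=O)N=C(C1=C(O)[C@H]3CCC[C@H]3N(Cc3ccc(F)c(F)c3)C1=O)N2` — in an ADME assay on Huh-7 cells (Homo sapiens) for cytotoxicity, with a stated time of 72 h (on this read-out lower numbers stand for higher toxicity in this test and higher numbers for lower toxicity in this test), compound 1 gives > 1000 nM, which is a limit of the assay and not a number.
compound 2 `CC(C)CCN1C(=O)C(C2=NS(=O)(=O)c3cc(NS(C)(=O)=O)ccc3N2)=C(O)[C@H]2CCC[C@H]21` — in this assay compound 2 gives > 1000 nM, again a limit.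
compound 3 `CS(=O)(=O)Nc1ccc2c(c1)S(=O)(=O)N=C(C1=C(O)[C@H]3CCC[C@H]3N(Cc3ccc(C(F)(F)F)cc3)C1=O)N2` — in this assay compound 3 gives > 33000 nM, also a limit.

Compound 3 therefore stands only at a limit, the one described in the limit of > 33000 nM in this assay, at which 1 of the 3 values shown sits; the other two compounds sit at the limit described in the limit of > 1000 nM in this assay, at which 2 of the 3 values shown sit. The steps a step that the two limits leave unreadable from compound 1 to compound 3 and a step that the two limits leave unreadable from compound 2 to compound 3 are unreadable, as is a step that the two limits leave unreadable from compound 1 to compound 2. Compound 4 `CS(=O)(=O)Nc1ccc2c(c1)S(=O)(=O)N=C(C1=C(O)[C@H]3CCC[C@H]3N(CC3CC3)C1=O)N2` differs from compound 3 by cyclopropyl in place of 4-(trifluoromethyl)phenyl on a saturated chain carbon bound to an amide-type nitrogen in a ring. Among the compounds with values here, no measured step gives a readable size, so nothing beyond the scatter is expected in this assay in either direction. The step of an at least 1.1-fold lower number from compound 3 to compound 4 (0.04 log units; that floor lies within the scatter) is an estimate only. Compound 4 is expected at 30000 nM, within 3000 nM to 100000 nM.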

Compound 4, half-maximal cytotoxic concentration: > 33000 nM
Compound 4 was reported as a limit; the forecaster's own chance of this, stated with the estimate: 85%; middle value at least 1.1-fold (0.04 log units) away from the limit.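

In this assay, within the data shown here, compound 4 gives > 33000 nM, a limit and not a number, so no step from compound 1, compound 2 or compound 3 to compound 4 can be read. As far as these compounds go, whether cyclopropyl, isobutyl, 3,4-difluorophenyl and 4-(trifluoromethyl)phenyl differ at all in this assay stays open.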